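Swapping bromine for chlorine on a weakly cytotoxic imine

The source may report more compounds than this note shows. Statements on the series, on what has been measured and on what is new or still open speak of the compounds shown alone.

Three compounds were tested in an ADME assay on MCF-10A cells (Homo sapiens) for cytotoxicity, read by sulforhodamine B assay, with a stated time of 48 h; on this read-out lower numbers stand for stronger inhibition of growth and higher numbers for weaker inhibition of growth. Compound 1 `CCN(CC)CN1C(=O)/C(=N\c2nc3ccc(C)cc3s2)c2ccccc21` gives 20400 nM. Compound 2 `Cc1ccc2nc(/N=C3\C(=O)N(CN(c4ccccc4)c4ccccc4)c4cccc(Br)c43)sc2c1` gives 67900 nM, and compound 3 `O=C1C(=O)N(CN2CCCCC2)c2cccc(Cl)c21` gives 70700 nM. Among these, compound 2 sits close to compound 3, a gap within the scatter, while its number is well above that of compound 1, a gap beyond the scatter. Compound 4 `Cc1ccc2nc(/N=C3\C(=O)N(CN(c4ccccc4)c4ccccc4)c4cccc(Cl)c43)sc2c1` is compound 2 with one change: chloro in place of bromo on an aromatic carbon. For the measured compounds named here, no measured pair in this set shows how such an exchange plays out here, so the expected step of a 1.0-fold lower number from compound 2 to compound 4 (0.02 log units; within the scatter) in this assay is small, with no clear direction beyond the scatter. Compound 4 is therefore expected to give about 65000 nM, with a likely range from 30000 nM to 140000 nM.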

Compound 4, concentration for 50% growth inhibition: 70000 nM
Compound 4: the middle estimate sits 1.1-fold (0.03 log units) below what was measured, and the stated range covers the measured number.
By their numbers in this assay, from the lowest: compound 1; then compounds 2, 4 and 3 (each within the scatter of the next).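

In this assay, for the compounds shown here, chloro in place of bromo on this aromatic carbon gives a 1.0-fold higher number from compound 2 to compound 4 (0.01 log units; within the scatter), the first measured pair in the set for this exchange. On this core, then, the two halogens give numbers that cannot be told apart, and growth inhibition stays weak with either one. Nothing measured here offers an explanation for this result.

Going by these compounds, whether a group of a different kind at this carbon, such as a methoxy group or an amine, would shift the number remains open. A carboxylic acid there poses the same open question.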